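This account rests on a few compounds, and the source may have more. Where it says the series, first, only, none or still open, it means among the compounds named here.

Working notes on the series. All compounds share one core and differ only in the aryl group on the nitrogen on the aromatic ring. Compound 1 `COc1cc2ncnc(Nc3ccc(Cl)c(C(F)(F)F)c3)c2cc1OCCCCC(=O)Nc1ccc(S(N)(=O)=O)cc1` gives 3220 nM in a functional assay on NCI-H1975 cells (Homo sapiens) for antiproliferative activity, read by MTT assay, with a stated time of 72 h; on this read-out lower numbers stand for stronger inhibition and higher numbers for weaker inhibition. Compound 2 `COc1cc2ncnc(Nc3cccc(Br)c3)c2cc1OCCCCC(=O)Nc1ccc(S(N)(=O)=O)cc1` gives 11400 nM in this assay, the step being a 3.5-fold higher number from compound 1 to compound 2 (0.55 log units; beyond the scatter). Compound 3 `COc1cc2ncnc(Nc3cccc(F)c3)c2cc1OCCCCC(=O)Nc1ccc(S(N)(=O)=O)cc1` is reported in this assay only as the limit > 40000 nM (the limit of > 40000 nM in this assay, at which 1 of the 3 values shown sits). Compound 3 therefore stands weakest of the three, with an at least 12-fold higher number from compound 1 to compound 3 (1.09 log units; beyond the scatter) and an at least 3.5-fold higher number from compound 2 to compound 3 (0.54 log units; beyond the scatter). Compound 4 `COc1cc2ncnc(Nc3ccc(Cl)cc3)c2cc1OCCCCC(=O)Nc1ccc(S(N)(=O)=O)cc1` differs from compound 3 by 4-chlorophenyl in place of 3-fluorophenyl on a nitrogen on an aromatic ring. The nearest measured step is an at least 3.5-fold higher number from compound 2 to compound 3 (0.54 log units; beyond the scatter), a halogen swap on the same ring; the reverse direction, a lower number, is expected here. Compound 4 is estimated at 15000 nM in this assay, range 4000 nM to 60000 nM, which is expected to mean an at least 2.6-fold lower number from compound 3 to compound 4 (0.42 log units; beyond the scatter).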

Compound 4, half-maximal inhibitory concentration: 31800 nM
Beside the measured number, compound 4's estimate is 2.1-fold (0.33 log units) below it; measured number inside the range.
By their numbers in this assay, from the lowest: compound 1; then compound 2; then compound 4. At a limit, above all of these: compound 3.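

Replacing 3-fluorophenyl with 4-chlorophenyl gives an at least 1.2-fold lower number from compound 3 to compound 4 (0.09 log units; that floor lies within the scatter), and compound 3 is only a limit, so the two groups cannot be ordered: the limit of > 40000 nM in this assay, at which 1 of the 4 values shown sits.

Against 3-bromophenyl, 4-chlorophenyl gives a 2.8-fold higher number from compound 2 to compound 4 (0.45 log units; beyond the scatter). Hydrogen in place of trifluoromethyl gives a 9.9-fold higher number from compound 1 to compound 4 (0.99 log units; beyond the scatter), so 4-chlorophenyl alone does not match the full group of compound 1.

Open, on these data alone, is whether 3-chlorophenyl or 3-(trifluoromethyl)phenyl would separate the identity of the substituent from its position on the ring. Also open, as far as these compounds go, is how an aryl group carrying an amine would rank.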